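Para substituent swap on the anilino core: compound 4

This account rests on a few compounds, and the source may have more. Where it says the series, first, only, none or still open, it means among the compounds named here.

In an assay on mitochondria from L6 cells (Rattus norvegicus) for activation, with a stated time of 90 min (on this read-out higher numbers stand for an effect only at larger amounts of compound and lower numbers for an effect already at smaller amounts), compound 2 `Oc1nc2nonc2nc1Nc1ccc(S(F)(F)(F)(F)F)cc1` gives 3900 nM, the second highest of the three numbers measured. Compound 1 `CCCCOc1ccc(Nc2nc3nonc3nc2O)cc1` gives 3700 nM, and the step of a 1.1-fold higher number from compound 1 to compound 2 (0.02 log units; within the scatter) is within the scatter. Compound 3 `Oc1nc2nonc2nc1Nc1cccc2ccccc12` gives 20400 nM, a number beyond the scatter from compound 2.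

Compound 4 `CC(C)(C)c1ccc(Nc2nc3nonc3nc2O)cc1` differs from compound 2 by a group of 4 heavy atoms (4 carbon; no ring) in place of a group of 6 heavy atoms (5 fluorine, 1 sulfur; no ring), on an aromatic carbon. Among the compounds with values here, the only step that bears on this is the one from compound 1 to compound 2, where swapping the group on the same aromatic carbon left the number unchanged within the scatter. No step beyond the scatter is therefore expected for compound 4, and the expected step of a 1.0-fold lower number from compound 2 to compound 4 (0.01 log units; within the scatter) is within the scatter. Compound 4 is expected to give about 3800 nM in this assay, in the range 1500 nM to 10000 nM.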

Compound 4, half-maximal effective concentration: 3900 nM
The estimate for compound 4 lay 1.0-fold (0.01 log units) below the measured number; low and high end bracket the measured number.
By their numbers in this assay, from the lowest: compounds 1, 2 and 4 (each within the scatter of the next); then compound 3.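

In this assay, tert-butyl on this aromatic carbon, para to a large group, reads level with both earlier groups: no change at the digits printed from compound 2 to compound 4 (within the scatter), and a 1.1-fold higher number from compound 1 to compound 4 (0.02 log units; within the scatter). An all-carbon group therefore joins butoxy and the group of fluorine and sulfur, with all three within the scatter of one another at this position. No evidence bears on why these groups read alike.

Still open, on these data alone, is whether an amine or a carboxylic acid on this carbon would move the number beyond the scatter. The same holds for a longer chain.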